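Ester side-chain variation in an antiproliferative series

The compounds below may be only part of what the source reports. "The series", "measured", "known", "first", "only" and "open" are said of these compounds alone.

Compound 1 `C/C=C1/[C@H](O[C@@H]2O[C@H](CO)[C@@H](O)[C@H](O)[C@H]2O)OC=C(C(=O)OC)[C@H]1CC(=O)OCCCc1ccc(OC)c(OC)c1` is assessed in a functional assay on SK-BR-3 cells (Homo sapiens) for antiproliferative activity, read by MTT assay, with a stated time of 72 h; a higher number here means a weaker inhibitor, a lower number a stronger inhibitor. In this assay compound 1 returns only a limit, > 20000 nM. Compound 2 `C/C=C1/[C@H](O[C@@H]2O[C@H](COC(C)=O)[C@@H](OC(C)=O)[C@H](OC(C)=O)[C@H]2OC(C)=O)OC=C(C(=O)O)[C@H]1CC(=O)O` likewise returns a limit, > 20000 nM. Compound 3 `C/C=C1/[C@H](O[C@@H]2O[C@H](COC(C)=O)[C@@H](OC(C)=O)[C@H](OC(C)=O)[C@H]2OC(C)=O)OC=C(C(=O)OC)[C@H]1CC(=O)OC` also gives a limit, > 15000 nM. Within the data shown here, two of the three values sit at the limit of > 20000 nM in this assay, at which 2 of the 3 values shown sit, and one at the limit of > 15000 nM in this assay, at which 1 of the 3 values shown sits, so no compound in the set has a measured number and compound 1 stands indistinguishable from the others. Compound 4 `C/C=C1/[C@H](O[C@@H]2O[C@H](CO)[C@@H](O)[C@H](O)[C@H]2O)OC=C(C(=O)OC)[C@H]1CC(=O)OCCc1ccc(O)cc1` differs from compound 1 by 4-hydroxyphenyl in place of 3,4-dimethoxybenzyl on a saturated chain carbon, two bonds along the chain from an oxygen next to a carbonyl group. Among the measured compounds shown here, no measured pair differs in one place, so no step size is known from these data. Compound 4 is expected to stay at the limit, with an expected step that the limit leaves unreadable from compound 1 to compound 4 and an estimate of 25000 nM, spanning 8000 nM to 80000 nM.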

Compound 4, half-maximal inhibitory concentration: > 20000 nM
Compound 4 was reported as a limit; the forecaster's own chance of this, stated with the estimate: 85%; the middle value lies beyond the limit too.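

In this assay compound 4 returns only a limit, > 20000 nM. Among these compounds, compound 1 is also a limit, so no step between compound 1 and compound 4 can be read. The compounds shown leave open whether any ester side chain on the shared core gives a measured number in this assay.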